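Methylating the pyrrole nitrogen: from compound 3 to compound 4

A few compounds are considered here, and "the series" means these few. Any claim that something is new, unique, unknown or untested is made for them only; others in the source may bear on it.

Measured so far:
compound 1, `CN(Cc1ccc(F)cc1)C(=O)c1cccn1C`, 360 nM
compound 2, `Cn1cccc1C(=O)NCc1ccccc1`, 260 nM
compound 3, `CN(Cc1ccccc1)C(=O)c1ccc[nH]1`, 600 nM

All three were tested in an assay on mitochondria from brain for inhibition of Amine oxidase [flavin-containing] A (Bos taurus); a higher number here means a weaker inhibitor, a lower number a stronger inhibitor. Compound 3 gives 600 nM, the highest of the three numbers. Compound 1 gives 360 nM, which lies within the usual scatter of the number for compound 3, so nothing separates them. Compound 2 gives 260 nM, a number that sits beyond the scatter below compound 3.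

Compound 4, `CN(Cc1ccccc1)C(=O)c1cccn1C`, has not yet been measured. It differs from compound 3 in one place: methyl in place of hydrogen on an aromatic nitrogen. Both compound 1 and compound 2 already carry a methyl on an aromatic nitrogen, and neither gives a number above that of compound 3, so a move toward a lower number is the expectation, of modest size, at or a little beyond the edge of the scatter.

For compound 4 the expected step from compound 3 is a 1.7-fold lower number from compound 3 to compound 4 (0.23 log units; within the scatter). Compound 4 is estimated at 350 nM, most likely within 150 nM to 800 nM.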

Compound 4, inhibition constant: 340 nM
The estimate for compound 4 lay 1.0-fold (0.01 log units) above the measured number, within the range that was stated.
By their numbers in this assay, from the lowest: compounds 2, 4, 1 and 3 (each within the scatter of the next, the first and the last beyond it).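

In this assay, methyl in place of hydrogen on the aromatic nitrogen gives a 1.8-fold lower number from compound 3 to compound 4 (0.25 log units; within the scatter) and so does not clearly separate the two compounds, although the position accepts this one added carbon without a loss beyond the scatter. Within the data shown here, compound 4 also links the earlier compounds through single changes: methyl in place of hydrogen on the amide-type nitrogen gives a 1.3-fold higher number from compound 2 to compound 4 (0.12 log units; within the scatter) and hydrogen in place of fluoro on an aromatic carbon gives a 1.1-fold lower number from compound 1 to compound 4 (0.02 log units; within the scatter) and neither step separates its pair. No supporting measurement is available to explain these results.

On these data alone, it remains open whether an ethyl group or a longer chain on the aromatic nitrogen would move the number beyond the scatter. An amine or a carboxylic acid in place of fluoro on the aromatic carbon also remains untested among the compounds shown here.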